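A few compounds are considered here, and "the series" means these few. Any claim that something is new, unique, unknown or untested is made for them only; others in the source may bear on it.

Compound 2 `O=C(Nc1ccc2cccnc2c1)c1ccc(-c2ccc(C(F)(F)F)cc2)nc1` was tested in an in vitro functional assay on 1321-N1 cells for antagonist activity at transient receptor potential cation channel subfamily V member 1 (Homo sapiens), read by FLIPR and calcium flux (on this read-out lower numbers stand for lower potency and higher numbers for higher potency (the scale is a negative logarithm)), where compound 2 gives 7.3. This is the only full number shown for the series. Compound 1 `O=C(Nc1ccc2cccnc2c1)c1ccc(Cl)nc1` shares the same core, and in this assay compound 1 gives < 6.7, which is a limit of the assay rather than a number. Given (the limit of < 6.7 in this assay, at which 1 of the 2 values shown sits), compound 2 stands alone as the one compound with a measured potency, and nothing can be said about its order against compound 1.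

Compound 3 `O=C(Nc1ccc2cccnc2c1)c1ccc(-c2ccc(F)cc2)nc1` has not yet been measured in this assay. The change from compound 2 to compound 3 is fluoro in place of trifluoromethyl on an aromatic carbon. Within the data shown here, no measured pair shows this change. The step is expected to be a number 0.30 log units lower from compound 2 to compound 3 (within the scatter), a small loss that may not exceed the usual scatter. Compound 3 is therefore estimated at 7, within a range from 6.4 to 7.6.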

Compound 3, negative logarithm of the antagonist equilibrium constant: 8.2
For compound 3 the middle estimate is 1.20 log units below the measured one; measured number outside the range, above it.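

In this assay, fluoro in place of trifluoromethyl gives a number 0.90 log units higher from compound 2 to compound 3 (beyond the scatter) and so shows that the group on this aromatic carbon, para to a large group, clearly affects potency, with the single fluorine atom doing better here than the four heavy atoms of trifluoromethyl. With 4-fluorophenyl in place of chloro on the shared core, the series also gains its first step of measurable size: a number at least 1.50 log units higher from compound 1 to compound 3 (beyond the scatter). Compound 1 gives < 6.7 as a limit of the assay and not a number, so this second step has no exact size: the limit of < 6.7 in this assay, at which 1 of the 3 values shown sits.

Among these compounds, with only two groups compared on this carbon, it remains unclear whether the size of the group or its nature drives the difference. An amine, a methoxy group or a carboxylic acid in the same place could help to separate the two.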